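Trimming an acyl urea to a vinyl amide

A few compounds are considered here, and "the series" means these few. Any claim that something is new, unique, unknown or untested is made for them only; others in the source may bear on it.

Compound 1, `CCCCC(O)c1cccc(NC(=O)NCCCCl)c1`: in a functional assay on HT-29 cells (Homo sapiens) for antiproliferative activity, with a stated time of 48 h (on this read-out lower numbers stand for stronger inhibition and higher numbers for weaker inhibition), compound 1 gives 19000 nM.
Compound 2, `CCCCC(O)c1cccc(NC(=O)NC(=O)CC)c1`: in this assay compound 2 stops at > 100000 nM, which is a limit of the assay and not a number.
Compound 3, `CCCCC(OC)c1cccc(NC(=O)NC(=O)CC)c1`: in this assay compound 3 likewise stops at > 100000 nM, again a limit.

Compound 2 thus stands at the limit of > 100000 nM in this assay, at which 2 of the 3 values shown sit. The step of an at least 5.2-fold higher number from compound 1 to compound 2 (0.72 log units; beyond the scatter) shows it at least modestly weaker than compound 1, while the step that the two limits leave unreadable from compound 2 to compound 3 cannot be read between two limits. Compound 4, `C=CC(=O)Nc1cccc(C(O)CCCC)c1`, differs from compound 2 by vinyl in place of propanoylamino on a carbonyl carbon. Within the data shown here, no measured step bears directly on this change: the one readable step, from compound 1 to compound 2, concerns the group on the urea nitrogen, not the carbonyl carbon, and the step from compound 2 to compound 3 concerns the oxygen on the saturated carbon. Among the measured compounds shown here, what remains is that compound 1, the only compound with a number rather than a limit, gives 19000 nM, and compound 4 shares its hydroxyl-bearing side chain. Compound 4 is therefore expected to land near compound 1 rather than at the limit, with wide uncertainty. Compound 4 is estimated at 20000 nM, between 4000 nM and 100000 nM, an expected step of an at least 5.0-fold lower number from compound 2 to compound 4 (0.69 log units; beyond the scatter).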

Compound 4, half-maximal inhibitory concentration: > 100000 nM
Compound 4 gave a limit, no number (the forecaster's own chance of this, stated with the estimate: 30%); middle value at least 5.0-fold (0.69 log units) from the limit.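

On the carbonyl carbon, vinyl in place of (3-chloropropyl)amino gives an at least 5.2-fold higher number from compound 1 to compound 4 (0.72 log units; beyond the scatter), so this second replacement at that place, like propanoylamino in compound 2, leaves no measurable inhibition in this assay. The step from compound 2 to compound 4 cannot be read, as both ends are limits, and the data therefore do not rank vinyl against propanoylamino. Among the groups shown on this carbonyl carbon, only (3-chloropropyl)amino gives a number, and the other compounds gather at a single limit: the limit of > 100000 nM in this assay, at which 3 of the 4 values shown sit.

The compounds shown leave open whether the number for compound 1 depends on the nitrogen on this carbonyl carbon, on the chlorine at the end of the chain, or on both, and a plain propylamino group or a 3-hydroxypropylamino group at the same place would begin to separate these. As far as these compounds go, how far compound 2, compound 3 and compound 4 lie past their limits also stays unknown, as does whether a longer chain on the carbonyl carbon would bring back a number.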